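This account rests on a few compounds, and the source may have more. Where it says the series, first, only, none or still open, it means among the compounds named here.

Working notes on the series. The three measured compounds share one core. Compound 1 is `CCC1C(=O)N(C)c2cnc(-n3ccnc3-c3ccc(F)cc3)nc2N1C1CCC(F)(F)C1`, compound 2 is `CCC1C(=O)N(C)c2cnc(-n3ccnc3-c3ccc(F)cc3)nc2N1c1ccc(C#N)cc1` and compound 3 is `CC[C@@H]1C(=O)N(C)c2cnc(-n3ccnc3-c3ccccc3)nc2N1CCC(F)(F)F`. In a physicochemical assay for lipophilicity (on this read-out higher numbers stand for higher lipophilicity and lower numbers for lower lipophilicity), compound 1 gives 3.1, compound 2 gives 2.7 and compound 3 gives 3.1. Among the measured compounds shown here, compound 2 therefore stands lowest of the three in this assay, separated from both others beyond the scatter, and the single one-place step in the set, a number 0.40 log units lower from compound 1 to compound 2 (beyond the scatter), is the exchange of 4-cyanophenyl for 3,3-difluorocyclopentyl on a nitrogen on an aromatic ring in a ring.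

Compound 4, `CCC1C(=O)N(C)c2cnc(-n3ccnc3-c3ccc(F)cc3)nc2N1c1ccc(F)cc1`, is not yet measured in this assay. Compared with compound 2 the change is fluoro in place of cyano on an aromatic carbon. For the measured compounds named here, no measured step swaps one substituent for another on the same aromatic carbon; the step from compound 1 to compound 2 exchanges the whole group on the ring nitrogen, so it bears on the present change only in that it places compound 2 at the low end of the set. On that footing, and on what the cyano group and the fluoro group usually contribute in this kind of measurement, the step for compound 4 is expected to go upward, beyond the scatter: a number 0.70 log units higher from compound 2 to compound 4 (beyond the scatter). The estimate for compound 4 in this assay is 3.4, within a range from 3 to 3.8.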

Compound 4, partition coefficient: 3.4
Compound 4: middle estimate and measured number agree at the digits printed, and the stated range covers the measured number.
By their numbers in this assay, from the lowest: compound 2; then compounds 1, 3 and 4 (each within the scatter of the next).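

In this assay, the exchange of cyano for fluoro gives the series its first reading of a substituent swap on one aromatic carbon, para to a large group: a number 0.70 log units higher from compound 2 to compound 4 (beyond the scatter). It also separates two outcomes at the ring nitrogen: 4-cyanophenyl in place of 3,3-difluorocyclopentyl gave a number 0.40 log units lower from compound 1 to compound 2 (beyond the scatter), whereas 4-fluorophenyl in that place gives a number 0.30 log units higher from compound 1 to compound 4 (within the scatter), so the number for an aryl group on this nitrogen depends here on the substituent that the phenyl carries, at least across compound 2 and compound 4. No measurement at hand accounts for the size of either step.

From the compounds shown here alone, the cyano-to-fluoro exchange rests on this single pair, so its size with any other group elsewhere on the shared core remains unknown. The compounds shown also leave open where an unsubstituted phenyl, a methoxy group, an amine or a carboxylic acid on that same aromatic carbon would fall in this assay, and whether the numbers for such groups would follow those of cyano and fluoro.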